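The source may hold more compounds than are shown below. What is called first, only, known or untested is meant among the compounds shown, and "the series" means these compounds.

Measured compounds:
- compound 1, `c1csc(-c2ccccc2OCC2=NCCN2)c1`, in a functional assay for activation of Alpha-1A adrenergic receptor (Homo sapiens), read by calcium flux (a higher number here means that more compound is needed for the effect, a lower number that less compound is needed), compound 1 gives 1 nM
- compound 2, `Cc1ccc(-c2ccccc2OCC2=NCCN2)s1`, in this assay compound 2 gives 25.1 nM

Compound 2 stands at the higher of the two numbers recorded in this assay; its nearest neighbour is compound 1, and the step from compound 1 to compound 2 is a 25-fold higher number from compound 1 to compound 2 (1.40 log units; beyond the scatter), brought about by a methyl in place of hydrogen on an aromatic carbon.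

The next compound, compound 3, `Cc1csc(-c2ccccc2OCC2=NCCN2)n1`, keeps the methyl and differs from compound 2 by 4-methyl-1,3-thiazol-2-yl in place of 5-methylthiophen-2-yl on an aromatic carbon. For the measured compounds named here, no measured step bears directly on this exchange of one five-membered aromatic ring for another: the only recorded step, from compound 1 to compound 2, concerns the methyl alone and is therefore no guide to the size or direction of the present change. Going by the values given here, with no comparable precedent, a step within the scatter, or at most a modest one in either direction, is the plain expectation for this assay. The step from compound 2 to compound 3 is accordingly expected to be a 1.6-fold higher number from compound 2 to compound 3 (0.20 log units; within the scatter). Compound 3 is estimated at 40 nM, with a range from 8 nM to 200 nM.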

Compound 3, half-maximal effective concentration: 25.1 nM
Compound 3: the middle estimate sits 1.6-fold (0.20 log units) above what was measured, within the range that was stated.
By their numbers in this assay, from the lowest: compound 1; then compounds 2 and 3 (each within the scatter of the next).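

In this assay the exchange of 5-methylthiophen-2-yl for 4-methyl-1,3-thiazol-2-yl gives no change at the digits printed from compound 2 to compound 3 (within the scatter) and so shows that, on this aromatic carbon, a five-membered aromatic ring with 2 hetero atoms reads the same as the one with 1 hetero atom, even with the methyl at another ring position. The thiophen-2-yl of compound 1 stays apart, with a 25-fold higher number from compound 1 to compound 3 (1.40 log units; beyond the scatter) matching in size a 25-fold higher number from compound 1 to compound 2 (1.40 log units; beyond the scatter) and leaving compound 1 alone at the low end, while compounds 2 and 3 share the higher number. Compound 3 differs from compound 1 in both the ring and the methyl, so this step alone cannot assign the change to either, and nothing available explains why the two methyl-bearing rings read alike.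

From the compounds shown here alone, it remains open whether a 1,3-thiazol-2-yl without the methyl would stand with compound 1 or with compounds 2 and 3. Also open, going by these compounds, is how an ethyl, a methoxy or an amine in place of the methyl would read in this assay on either ring.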